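Methoxy for Methyl on the Aryl Group of Compound 2

This account rests on a few compounds, and the source may have more. Where it says the series, first, only, none or still open, it means among the compounds named here.

Measured compounds:
- compound 1, `COc1ccc(-c2c(C=O)c3cc(C#N)c(C#N)cc3n2OC)cc1`, 147 nM
- compound 2, `COn1c(-c2ccc(C)cc2)c(CO)c2cc(C#N)c(C#N)cc21`, 5120 nM

Of the compounds shown here, two have been tested in an assay on isolated protein for inhibition of Amine oxidase [flavin-containing] A (Homo sapiens), read by fluorescence and spectrophotometry, with a stated time of 20 min; on this read-out lower numbers stand for stronger inhibition and higher numbers for weaker inhibition. Compound 1 gives 147 nM, while compound 2 gives 5120 nM, the higher of the two numbers and therefore the weaker inhibitor of the pair; the gap between them lies well beyond the usual scatter. The two structures differ in two places at once, so their values alone do not tell which change matters more.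

Compound 3, `COc1ccc(-c2c(CO)c3cc(C#N)c(C#N)cc3n2OC)cc1`, has not yet been measured. It differs from compound 2 in one place: methoxy in place of methyl on an aromatic carbon. For the measured compounds named here, the aryl group of compound 3 matches that of compound 1, but the rest of compound 3 follows compound 2, so no measured step isolates this change. A modest move toward a lower number in this assay is expected, though one that may not exceed the scatter. The step from compound 2 to compound 3 is estimated at a 2.0-fold lower number from compound 2 to compound 3 (0.31 log units; beyond the scatter). Compound 3 is therefore expected to give 2500 nM, within a range from 800 nM to 8000 nM.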

Compound 3, half-maximal inhibitory concentration: 1130 nM
Estimate against measurement, compound 3: 2.2-fold (0.34 log units) above; measured number inside the range.
By their numbers in this assay, from the lowest: compound 1; then compound 3; then compound 2.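

In this assay, for the compounds shown here, the change from 4-methylphenyl to 4-methoxyphenyl gives a 4.5-fold lower number from compound 2 to compound 3 (0.66 log units; beyond the scatter) and so shows, for the first time on its own, that the group on this aromatic carbon, para to a large group, affects the read-out. With the 4-methoxyphenyl group held fixed, hydroxymethyl in place of formyl gives a 7.7-fold higher number from compound 1 to compound 3 (0.89 log units; beyond the scatter) and separates the second difference from the first, so each change alone moves the number beyond the usual scatter. Nothing among the available data explains why either change has this effect.

On these data alone, each change is seen only once, so it remains open whether methoxy in place of methyl would give a step of similar size on a compound that carries formyl rather than hydroxymethyl. It is also unknown how this position would respond to other groups, such as a hydroxyl, an amine, a chlorine atom or a longer chain like ethoxy, and therefore whether methoxy is specifically favorable or merely one of several groups that give a lower number than methyl.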